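The compounds below may be only part of what the source reports. "The series", "measured", "known", "first", "only" and "open" are said of these compounds alone.

Measured so far in an ADME assay on RAW264.7 cells (Mus musculus) for cytotoxicity, read by neutral red uptake, with a stated time of 24 h (a lower number here means that less compound is tolerated, a higher number that more compound is tolerated), each value being a limit of the assay and not a number:

- Compound 1 `C=CCONC(=O)CN1C(=O)CSC1=O`: > 128000 nM
- Compound 2 `C=CCONC(=O)CN1C(=O)S/C(=C\c2ccccc2)C1=O`: > 128000 nM
- Compound 3 `C=CCONC(=O)C(C)N1C(=O)S/C(=C\c2ccccc2)C1=O`: > 128000 nM

Compound 2 therefore has no exact position on the scale. All that can be said is that it sits at the limit of > 128000 nM in this assay, at which 3 of the 3 values shown sit. Going by the values given here, no measured compound in this small set has yet given a number, so none can be ranked against another.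

Compound 4 `C=CCONC(=O)CN1C(=O)S/C(=C\c2ccc(C(F)(F)F)cc2)C1=O` differs from compound 2 in one place: trifluoromethyl in place of hydrogen on an aromatic carbon. This is trifluoromethyl in place of hydrogen on an aromatic carbon.

Among the compounds with values here, only one measured step is available as a guide, a step that the two limits leave unreadable from compound 2 to compound 3. It offers no size to carry over, and it concerns a methyl on a saturated chain carbon rather than a change on an aromatic carbon. The data therefore give no measured reason to expect a shift in either direction. For compound 2, the expectation rests on > 128000 nM, which is a limit. In this assay, the expected change is a number no higher from compound 2 to compound 4 (the limit leaves the size open), an estimate of no step beyond the usual scatter. Compound 4 is estimated at 128000 nM, with an expected range of 50000 nM to 300000 nM.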

Compound 4, half-maximal cytotoxic concentration: > 128000 nM
Compound 4 was reported as a limit; the forecaster's own chance of this, stated with the estimate: 70%; the middle value lies on the limit itself.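

In this assay compound 4 gives > 128000 nM, which is a limit of the assay and not a number. Compound 2 also stands at a limit, so no step between compound 2 and compound 4 can be read: the limit of > 128000 nM in this assay, at which 4 of the 4 values shown sit.

The compounds shown leave open at what concentration any of them would harm these cells, and whether trifluoromethyl changes that concentration.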